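Acetylating the Ring Hydroxyl of a Weakly Cytotoxic Lactone

The compounds below may be only part of what the source reports. "The series", "measured", "known", "first", "only" and "open" are said of these compounds alone.

Compound 1 `CC(=O)O[C@@H]1OC(=O)[C@](Cc2ccccc2)(C(C)=O)[C@@H]1C` gives 40000 nM in a functional assay on HT-29 cells (Homo sapiens) for cytotoxicity, read by MTT assay; on this read-out higher numbers stand for weaker inhibition and lower numbers for stronger inhibition.
Compound 2 `CC(=O)O[C@@H]1OC(=O)[C@](O)(C(C)=O)[C@@H]1C` reaches only a limit of this assay, > 50000 nM.

Compound 2 therefore sits at the limit of > 50000 nM in this assay, at which 1 of the 2 values shown sits, and only a limit, not a number, is known for it. Going by the values given here, the single measured step, an at least 1.2-fold higher number from compound 1 to compound 2 (0.09 log units; that floor lies within the scatter), replaces benzyl with hydroxy and does not touch the hydroxy itself. Compound 3 `CC(=O)O[C@@H]1OC(=O)[C@](OC(C)=O)(C(C)=O)[C@@H]1C` differs from compound 2 by acetyl in place of hydrogen on an oxygen on a saturated carbon. Among the compounds with values here, no measured step covers this change, so the expected step of a number no higher from compound 2 to compound 3 (the limit leaves the size open) is none beyond the scatter. In this assay compound 3 is estimated at 50000 nM, within a range from 20000 nM to 150000 nM.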

Compound 3, half-maximal inhibitory concentration: > 50000 nM
Compound 3 was reported as a limit; the forecaster's own chance of this, stated with the estimate: 60%; the middle value sits exactly at the limit.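

In this assay, compound 3 joins compound 2 at a limit rather than a number: the limit of > 50000 nM in this assay, at which 2 of the 3 values shown sit.

The step between these two compounds cannot be read, so adding the acetyl to the hydroxy shows no measurable effect in either direction. Acetoxy in place of benzyl gives an at least 1.2-fold higher number from compound 1 to compound 3 (0.09 log units; that floor lies within the scatter), so this change is not shown to exceed the scatter.

Going by these compounds, the actual values of compound 2 and compound 3 remain open. Also open, on these data alone, is how an amine or a carboxylic acid at this position would compare with benzyl in this assay.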